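A few compounds are considered here, and "the series" means these few. Any claim that something is new, unique, unknown or untested is made for them only; others in the source may bear on it.

Compound 1 `O=C(CCCCCCc1cccc(F)c1)N1CCCC1` and compound 2 `O=C(O)c1cccc(CCCCCCC(=O)N2CCCC2)c1` share one core. In an assay on HEK293 cells for inhibition of N-acylethanolamine-hydrolyzing acid amidase (Rattus norvegicus), read by LC-MS, with a stated time of 30 min (a lower number here means a stronger inhibitor, a higher number a weaker inhibitor), compound 1 gives 7300 nM. Compound 2 reaches only the limit of this assay, > 100000 nM. Compound 2 thus sits at the limit of > 100000 nM in this assay, at which 1 of the 2 values shown sits. Among the measured compounds shown here, the single measured step, an at least 13-fold higher number from compound 1 to compound 2 (1.13 log units; beyond the scatter), is the only one that bears on the change to compound 3 `COC(=O)c1cccc(CCCCCCC(=O)N2CCCC2)c1`, which is methyl in place of hydrogen on an oxygen next to a carbonyl group. For the measured compounds named here, no measured step covers this change itself, so any expectation for compound 3 must stay wide. Compound 3 is estimated at 30000 nM, with a range of 5000 nM to 150000 nM, an expected step of an at least 3.3-fold lower number from compound 2 to compound 3 (0.52 log units; beyond the scatter).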

Compound 3, half-maximal inhibitory concentration: > 100000 nM
Compound 3: a limit, no number; the forecaster's own chance of this, stated with the estimate: 40%; middle value at least 3.3-fold (0.52 log units) from the limit.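

With methoxycarbonyl in place of fluoro on the aromatic carbon, this assay shows an at least 13-fold higher number from compound 1 to compound 3 (1.13 log units; beyond the scatter). The loss seen with carboxy therefore also appears with its methyl ester, so it does not depend on the free acid alone. Compound 2 and compound 3 both give only limits, so the step between them cannot be read: the limit of > 100000 nM in this assay, at which 2 of the 3 values shown sit.

From the compounds shown here alone, what remains open is whether any difference separates compound 2 from compound 3 beyond that limit. Going by these compounds, it is also open whether an amine or chlorine on that aromatic carbon, or a longer chain, would keep a value near that of compound 1.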